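The source may hold more compounds than are shown below. What is called first, only, known or untested is meant among the compounds shown, and "the series" means these compounds.

Measured compounds:
- compound 1 `CCCNc1nc2ccc(-c3cnc(Cl)c(NS(=O)(=O)c4ccc(F)cc4)c3)cc2s1`: "not determined" (no result reported) in a functional assay on MCF7 cells (Homo sapiens) for antiproliferative activity, read by MTT assay, with a stated time of 72 h; a lower number here means a stronger inhibitor, a higher number a weaker inhibitor
- compound 2 `CNC(=O)Nc1nc2ccc(-c3cnc(OC)c(NS(=O)(=O)c4ccc(F)cc4)c3)cc2s1`: 1190 nM
- compound 3 `CCN(CC)CCNC(=O)Nc1nc2ccc(-c3cnc(Cl)c(NS(=O)(=O)c4ccc(F)cc4)c3)cc2s1`: 710 nM

Going by the values given here, only two numbers exist in this assay. Compound 2 holds the higher of the two, but its gap to compound 3 lies within the usual scatter, so the two are not separated by the data. Among the compounds with values here, compound 3 differs from compound 2 in more than one place, and no single-point step between measured compounds is available. Compound 1 contributes nothing numerical.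

Compound 4 `COc1ncc(-c2ccc3nc(NC(=O)NCCN(C)C)sc3c2)cc1NS(=O)(=O)c1ccc(F)cc1` is the next entry. Relative to compound 2 the change is (dimethylamino)methyl in place of hydrogen on a saturated chain carbon bound to an amide-type nitrogen. Everything else, including the methoxy-bearing substituted pyridine and the sulfonamide, stays as in compound 2.

Within the data shown here, with no measured step to lean on, the expectation rests on the two numbers at hand. Compound 3, which also carries a longer amine-bearing chain on the urea, sits at 710 nM, close to compound 2. The step of a 1.5-fold lower number from compound 2 to compound 4 (0.17 log units; within the scatter) is therefore expected to be small, if anything toward a lower number, and not clearly beyond the scatter. Compound 4 is estimated at 800 nM, with a likely range from 350 nM to 1800 nM.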

Compound 4, half-maximal inhibitory concentration: 500 nM
Estimate against measurement, compound 4: 1.6-fold (0.20 log units) above, within the range that was stated.
By their numbers in this assay, from the lowest: compounds 4, 3 and 2 (each within the scatter of the next, the first and the last beyond it).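

In this assay, going by these compounds alone, exchanging methylcarbamoyl for (2-(dimethylamino)ethyl)carbamoyl gives a 2.4-fold lower number from compound 2 to compound 4 (0.38 log units; beyond the scatter), a modest change and the only step that isolates one place. Within the data shown here, compound 3 also carries an amine-bearing chain but differs from compound 2 in more than one place, so only this step shows that adding (dimethylamino)methyl on the saturated chain carbon bound to an amide-type nitrogen, with the methoxy group and the sulfonamide unchanged, is accompanied by a lower number. No measurement shown here accounts for the size or direction of this step.

From the compounds shown here alone, it remains open whether the terminal amine itself matters at this place: a methoxymethyl group, a carboxylic acid, a morpholine or a longer chain at the same carbon would test this. Going by these compounds, compound 3 and compound 4 differ in more than one place, so it is also open whether the same chain change would give a comparable step in a compound carrying chloro instead of methoxy.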